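The compounds below may be only part of what the source reports. "The series", "measured", "known", "first", "only" and "open" are said of these compounds alone.

In an ADME assay on HepG2 cells (Homo sapiens) for cytotoxicity, read by neutral red uptake, with a stated time of 24 h (on this read-out higher numbers stand for weaker inhibition and lower numbers for stronger inhibition), compound 1 `CC(C)C(=O)Oc1c(C(C)C)cc2c3c1OC(=O)[C@@]31CCCC(C)(C)[C@@H]1CC2` gives 112000 nM as a measured number. Compound 2 `CCCCCCCCCCCC(=O)Oc1c(C(C)C)cc2c3c1OC(=O)[C@@]31CCCC(C)(C)[C@@H]1CC2` gives > 1000000 nM which is a limit of the assay and not a number. Compound 3 `CC(C)c1cc2c3c(c1OC(=O)CCCc1c[nH]c4ccccc14)OC(=O)[C@@]31CCCC(C)(C)[C@@H]1CC2` differs from compound 2 by 1H-indol-3-yl in place of octyl on a saturated chain carbon, three bonds along the chain from a carbonyl carbon on a saturated chain carbon, three bonds along the chain from a carbonyl carbon. For the measured compounds named here, the one measured step bearing on this, an at least 8.9-fold higher number from compound 1 to compound 2 (0.95 log units; beyond the scatter) with undecyl in place of isopropyl on a carbonyl carbon, is at least modest. With undecyl replaced by 3-(1H-indol-3-yl)propyl, a lower number is expected, moving toward compound 1 at 112000 nM in this assay without necessarily reaching it. The expected move, an at least 2.8-fold lower number from compound 2 to compound 3 (0.45 log units; beyond the scatter) toward lower numbers, is modest. The estimate for compound 3 is 350000 nM as a middle value (100000 nM to 1000000 nM).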

Compound 3, half-maximal inhibitory concentration: 120000 nM
Estimate against measurement, compound 3: 2.9-fold (0.46 log units) above; the range from low to high includes it.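

In this assay, the long chain on the carbonyl carbon does not by itself set the reading: 1H-indol-3-yl in place of octyl gives an at least 8.3-fold lower number from compound 2 to compound 3 (0.92 log units; beyond the scatter). With 3-(1H-indol-3-yl)propyl in place of isopropyl, the comparison with the short group gives a 1.1-fold higher number from compound 1 to compound 3 (0.03 log units; within the scatter), so this large end group reads like isopropyl. Compound 2 carries a limit and not a number, so the first step has no upper size: the limit of > 1000000 nM in this assay, at which 1 of the 3 values shown sits.

Still open, going by these compounds, is whether a phenyl group in place of 1H-indol-3-yl reads the same. On these data alone, how an amine or a carboxylic acid at the chain end would read also remains open.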